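Trifluoromethyl in place of fluoro on the indole ring

The source may hold more compounds than are shown below. What is called first, only, known or untested is meant among the compounds shown, and "the series" means these compounds.

Measured compounds:
- compound 1, `COC(=O)[C@@]1(C)CCC=C2[C@@H]1CC[C@@H](C)[C@]2(C)Cc1c[nH]c2ccc(C)cc12`: 22000 nM
- compound 2, `COC(=O)[C@@]1(C)CCC=C2[C@@H]1CC[C@@H](C)[C@]2(C)Cc1c[nH]c2ccc(Br)cc12`: 20000 nM
- compound 3, `COC(=O)[C@@]1(C)CCC=C2[C@@H]1CC[C@@H](C)[C@]2(C)Cc1c[nH]c2ccc(F)cc12`: 8000 nM

The three compounds share one core and differ only in the group on an aromatic carbon of the indole part. In a functional assay on WiDr cells (Homo sapiens) for inhibition, read by sulforhodamine B assay, with a stated time of 48 h (a lower number here means a stronger inhibitor of growth, a higher number a weaker inhibitor of growth), compound 1 gives 22000 nM, compound 2 gives 20000 nM and compound 3 gives 8000 nM. Compound 3 stands lowest of the three, and both steps toward it lie beyond the scatter: a 2.8-fold lower number from compound 1 to compound 3 (0.44 log units; beyond the scatter) and a 2.5-fold lower number from compound 2 to compound 3 (0.40 log units; beyond the scatter). The step between the methyl and bromo compounds is a 1.1-fold lower number from compound 1 to compound 2 (0.04 log units; within the scatter).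

Compound 4, `COC(=O)[C@@]1(C)CCC=C2[C@@H]1CC[C@@H](C)[C@]2(C)Cc1c[nH]c2ccc(C(F)(F)F)cc12`, is compound 3 altered in one place: trifluoromethyl in place of fluoro on an aromatic carbon. Among the compounds with values here, no measured step replaces fluoro by trifluoromethyl, so nothing bears on it directly. What the data show is that the two other groups measured at this position, methyl and bromo, each gave a higher number than fluoro in this assay, by the modest steps quoted. Compound 4 is therefore expected to give a number higher than compound 3, by a modest step, a 2.0-fold higher number from compound 3 to compound 4 (0.30 log units; within the scatter), though a result within the scatter cannot be ruled out. The estimate for compound 4 in this assay is 16000 nM, with a range from 6000 nM to 40000 nM.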

Compound 4, concentration for 50% growth inhibition: 18000 nM
The estimate for compound 4 lay 1.1-fold (0.05 log units) below the measured number; the measured number falls inside the stated range.
By their numbers in this assay, from the lowest: compound 3; then compounds 4, 2 and 1 (each within the scatter of the next).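

In this assay, trifluoromethyl gives a result closer to methyl and bromo than to fluoro, with a 2.3-fold higher number from compound 3 to compound 4 (0.35 log units; beyond the scatter) as the step away from fluoro. Compound 4 cannot be told apart from the bromo and methyl compounds, with a 1.1-fold lower number from compound 2 to compound 4 (0.05 log units; within the scatter) and a 1.2-fold lower number from compound 1 to compound 4 (0.09 log units; within the scatter) as the steps, so three quite different groups on this aromatic carbon now sit together within the scatter while fluoro alone stands lower. The difference between fluoro and the other three groups remains unexplained, as no measurement bearing on its cause is available.

The compounds shown leave open whether chloro, a methoxy group, a nitrile or an amine on this carbon would match fluoro or fall with the other three, and whether plain hydrogen there would give a lower or a higher number than fluoro. They also leave open whether the fluoro advantage would persist with a carboxylic acid in place of the methyl ester on the shared core, or with fluoro on another carbon of the same six-membered aromatic ring.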